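Extending the Ester of Compound 3 with a Diethylamino Chain

A few compounds are considered here, and "the series" means these few. Any claim that something is new, unique, unknown or untested is made for them only; others in the source may bear on it.

Three measured compounds share one core and differ only in the group on a saturated chain carbon bound to an aromatic carbon. Compound 1 `CCOCc1c(C)coc1-c1ccc2c(CC)cccc2c1OC` carries an ethoxy group there. In a functional assay on A549 cells (Homo sapiens) for cytotoxicity, read by MTT assay, with a stated time of 72 h (on this read-out higher numbers stand for an effect only at larger amounts of compound and lower numbers for an effect already at smaller amounts), compound 1 gives > 10 ug/mL, which is a limit of the assay and not a number. Compound 2 `CCc1cccc2c(OC)c(-c3occ(C)c3CBr)ccc12` carries a bromo group instead. In this assay compound 2 gives > 10 ug/mL, again only a limit. Compound 3 `CCc1cccc2c(OC)c(-c3occ(C)c3COC(C)=O)ccc12` carries an acetoxy group. In this assay compound 3 gives > 10 ug/mL, also a limit. Because (the limit of > 10 ug/mL in this assay, at which 3 of the 3 values shown sit), none of the steps among these three can be read: a step that the two limits leave unreadable from compound 1 to compound 2, a step that the two limits leave unreadable from compound 1 to compound 3 and a step that the two limits leave unreadable from compound 2 to compound 3 all remain without a size.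

Compound 4 `CCc1cccc2c(OC)c(-c3occ(C)c3COC(=O)CCN(CC)CC)ccc12` lengthens the ester of compound 3 by (diethylamino)methyl in place of hydrogen on a saturated chain carbon bound to a carbonyl carbon. Among the compounds with values here, no measured step bears on this change, since every known value sits at a limit. The step expected here is a step that the limit leaves unreadable from compound 3 to compound 4, with its direction uncertain. Compound 4 is expected to give about 15 ug/mL in this assay, with a plausible range from 5 ug/mL to 50 ug/mL, and a real chance that the result is once more only a limit.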

Compound 4, concentration for half-maximal effect: > 10 ug/mL
Compound 4 gave a limit, no number; the forecaster's own chance of this, stated with the estimate: 60%; the middle value does not contradict the limit.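

In this assay compound 4 gives > 10 ug/mL as a limit of the assay, not a number. The steps to compound 4 from compound 1, compound 2 and compound 3 therefore cannot be read, for one reason: the limit of > 10 ug/mL in this assay, at which 4 of the 4 values shown sit.

The compounds shown leave open whether any of these groups on the shared core changes the effect on the cells, and by how much.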